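Swapping the aryl on the carbonyl: compound 2 to compound 3

A few compounds are considered here, and "the series" means these few. Any claim that something is new, unique, unknown or untested is made for them only; others in the source may bear on it.

Measured compounds:
compound 1 `COc1ccc(-c2cc(/C=C/C(=O)c3ccc(N)cc3)[nH]n2)cc1`: -89%
compound 2 `COc1cc(-c2cc(/C=C/C(=O)c3ccc(Cl)c(Cl)c3)[nH]n2)cc(OC)c1OC`: 63%

In a functional assay on UACC-62 cells (Homo sapiens) for cytotoxicity, read by sulforhodamine B assay, with a stated time of 48 h, tested at 10 uM (on this read-out lower numbers stand for a stronger effect and higher numbers for a weaker effect at the one concentration tested), compound 2 gives the higher of the two numbers, the weaker effect, with compound 1 far lower, beyond the scatter. Compound 3 `COc1ccc(C(=O)/C=C/c2cc(-c3cc(OC)c(OC)c(OC)c3)n[nH]2)cc1` differs from compound 2 in one place: 4-methoxyphenyl in place of 3,4-dichlorophenyl on a carbonyl carbon. Among the measured compounds shown here, no measured pair shows this change, so the step from compound 2 to compound 3 is uncertain; a moderate fall in the number is expected, as a number 43 percentage points lower from compound 2 to compound 3 (beyond the scatter). For compound 3 the estimate is 20%, within -40% to 70%.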

Compound 3, a percentage reported as activity, at one concentration (the size of the read-out at that concentration, not a potency): -74%
Compound 3: middle estimate off by 94 percentage points, on the high side; the measured number lies below the stated range.
By their numbers in this assay, from the lowest: compound 1; then compound 3; then compound 2.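

In this assay, the aryl group on the carbonyl carbon turns out to matter greatly: 4-methoxyphenyl in place of 3,4-dichlorophenyl gives a large step of a number 137 percentage points lower from compound 2 to compound 3 (beyond the scatter) with everything else held the same. Among the compounds shown here, this is the first pair differing in one place, so the earlier compounds could not isolate this position. Nothing available here explains the size of the step.

As far as these compounds go, whether the methoxy group or the loss of the two chlorines drives the change stays open. A plain phenyl or a 4-chlorophenyl on this carbon would help separate the two.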